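This account rests on a few compounds, and the source may have more. Where it says the series, first, only, none or still open, it means among the compounds named here.

Measured so far:
compound 1 `Cc1cccc(N2CCN(c3nc(C(F)(F)F)ccc3CNC(=O)C(C)c3ccc(NS(C)(=O)=O)c(F)c3)CC2)c1`, 3.4 nM
compound 2 `CC(C(=O)NCc1ccc(C(F)(F)F)nc1N1CCN(c2ncccc2Cl)CC1)c1ccc(NS(C)(=O)=O)c(F)c1`, 2.1 nM
compound 3 `CC(C(=O)NCc1ccc(C(F)(F)F)nc1N1CCN(c2ncccc2C(F)(F)F)CC1)c1ccc(NS(C)(=O)=O)c(F)c1`, 2.8 nM

In a functional assay on CHO-K1 cells for antagonist activity at transient receptor potential cation channel subfamily V member 1 (Homo sapiens), read by FLIPR (a higher number here means a weaker inhibitor, a lower number a stronger inhibitor), compound 3 stands second highest of these three numbers, with compound 1 nearest and compound 2 furthest, and every gap lies within the scatter. Compound 4 `CC(C(=O)NCc1ccc(C(F)(F)F)nc1N1CCN(Cc2ccccc2)CC1)c1ccc(NS(C)(=O)=O)c(F)c1` differs from compound 3 by benzyl in place of 3-(trifluoromethyl)pyridin-2-yl on an amine nitrogen in a ring. Among the compounds with values here, two measured steps touch the same ring nitrogen: a 1.2-fold lower number from compound 1 to compound 3 (0.08 log units; within the scatter) and a 1.3-fold higher number from compound 2 to compound 3 (0.12 log units; within the scatter), both swapping one aromatic ring for another and both within the scatter. Within the data shown here, a benzyl group on that nitrogen has no counterpart among the measured compounds, so the expectation for compound 4 is only a modest shift, a 2.9-fold higher number from compound 3 to compound 4 (0.46 log units; beyond the scatter), toward a higher number. Compound 4 is therefore estimated at 8 nM, within a range from 2 nM to 30 nM.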

Compound 4, inhibition constant: 8.8 nM
Compound 4: middle estimate off by 1.1-fold (0.04 log units), on the low side, and the stated range covers the measured number.
By their numbers in this assay, from the lowest: compounds 2, 3 and 1 (each within the scatter of the next); then compound 4.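

In this assay, within the data shown here, swapping one aromatic ring for another on this ring nitrogen stayed within the scatter, but benzyl is the first group here to move the number beyond it: a 3.1-fold higher number from compound 3 to compound 4 (0.50 log units; beyond the scatter), a 4.2-fold higher number from compound 2 to compound 4 (0.62 log units; beyond the scatter) and a 2.6-fold higher number from compound 1 to compound 4 (0.41 log units; beyond the scatter). All three steps are modest, so this position responds to the change without losing activity at the nanomolar level. Nothing available explains the shift. Going by these compounds, it remains open how a plain methyl, a benzoyl or a longer chain such as phenylethyl on this nitrogen would compare.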